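Acetyl on the amino group of compound 3

The source may report more compounds than this note shows. Statements on the series, on what has been measured and on what is new or still open speak of the compounds shown alone.

In a functional assay on K562 cells (Homo sapiens) for inhibition, read by MTT assay, with a stated time of 48 h (a higher number here means a weaker inhibitor, a lower number a stronger inhibitor), compound 3 (`Nc1n[nH]c2cc(-c3cn([C@@H]4CN[C@H](C(=O)Nc5ccc(Br)cc5)C4)nn3)ccc12`) gives 10300 nM as the second highest of three numbers. Compound 1 (`CC(=O)Nc1n[nH]c2cc(-c3cn([C@@H]4CN[C@H](C(=O)Nc5ccc(Cl)c(C(F)(F)F)c5)C4)nn3)ccc12`) gives 15500 nM and lies within the scatter of compound 3. Compound 2 (`CC(=O)Nc1n[nH]c2cc(-c3cn([C@@H]4CN[C@H](C(=O)Nc5ccc(Cl)cc5Cl)C4)nn3)ccc12`) gives 2090 nM and lies lower than compound 3, beyond the scatter.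

Compound 4 (`CC(=O)Nc1n[nH]c2cc(-c3cn([C@@H]4CN[C@H](C(=O)Nc5ccc(Br)cc5)C4)nn3)ccc12`) differs from compound 3 by a single change (acetyl in place of hydrogen on a nitrogen on an aromatic ring): acetyl in place of hydrogen on a nitrogen on an aromatic ring, which reads as amino to acetamido.

Among the measured compounds shown here, no measured pair isolates this change. For the measured compounds named here, the one measured step (a 7.4-fold lower number from compound 1 to compound 2 (0.87 log units; beyond the scatter)) puts 2,4-dichlorophenyl in place of 4-chloro-3-(trifluoromethyl)phenyl on an amide-type nitrogen, with acetamido present on both sides. It shows a modest movement from the amide substituent alone and says nothing directly about acetyl. Compound 3 carries the amino group, and its 10300 nM sits inside the span set by the two acetamido compounds, so the data give no direction. No step beyond the scatter is therefore expected in this assay, and the estimated shift (a 1.3-fold lower number from compound 3 to compound 4 (0.11 log units; within the scatter)) stays small, with a wide margin. For compound 4 the expected value is 8000 nM (estimated range 2500 nM to 25000 nM).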

Compound 4, half-maximal inhibitory concentration: 3830 nM
Beside the measured number, compound 4's estimate is 2.1-fold (0.32 log units) above it; the measured number falls inside the stated range.
By their numbers in this assay, from the lowest: compounds 2 and 4 (each within the scatter of the next); then compounds 3 and 1 (each within the scatter of the next).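

Working notes: in this assay, the 4-bromophenyl pair gives the first isolated reading of acetyl in place of hydrogen on a nitrogen on an aromatic ring, and amino to acetamido gives a 2.7-fold lower number from compound 3 to compound 4 (0.43 log units; beyond the scatter), a modest step towards the stronger side that the earlier compounds could not show. With acetamido held constant, changing only the amide substituent gives a 1.8-fold higher number from compound 2 to compound 4 (0.26 log units; within the scatter) and a 4.0-fold lower number from compound 1 to compound 4 (0.61 log units; beyond the scatter), so 4-bromophenyl is within the scatter of 2,4-dichlorophenyl but separated, beyond the scatter, from 4-chloro-3-(trifluoromethyl)phenyl. No available measurement bears on the origin of the acetyl step.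

Going by these compounds, the acetyl step is read on the 4-bromophenyl amide alone, so its size with 2,4-dichlorophenyl or 4-chloro-3-(trifluoromethyl)phenyl remains open. Also open, on these data alone, is whether a longer acyl chain such as butanoyl, or a methanesulfonyl group, on the same nitrogen would give a number like that of acetyl or return towards that of the free amino group.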